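Fluorophenyl Carbamoyl Replaces Fluoropyridinyl Carbonyl on a Shared Core

The compounds below may be only part of what the source reports. "The series", "measured", "known", "first", "only" and "open" are said of these compounds alone.

Compound 1 `CNC(=O)c1cc(Oc2ccc3nc(NC(=O)c4ccc(Cl)cc4)sc3c2)ccn1`: 80.5%
Compound 2 `CNC(=O)c1cc(Oc2ccc3nc(NC(=O)Nc4ccc(N5CCN(C)CC5)cc4)sc3c2)ccn1`: 95%
Compound 3 `CNC(=O)c1cc(Oc2ccc3nc(NC(=O)c4cccc(F)n4)sc3c2)ccn1`: 55.5%

Of the compounds shown here, three built on one shared core have been tested in a functional assay on HCT-116 cells (Homo sapiens) for inhibition, read by MTT assay, with a stated time of 2 days, tested at 100 uM; a higher number here means more inhibition of growth at the concentration tested, a lower number less inhibition of growth. Compound 3 gives 55.5%, the lowest of the three numbers. Compound 1 gives 80.5%, and compound 2 gives 95%, the highest of the three, both of them beyond the scatter away from compound 3.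

Compound 4 `CNC(=O)c1cc(Oc2ccc3nc(NC(=O)Nc4ccc(F)cc4)sc3c2)ccn1` differs from compound 3 in one place: (4-fluorophenyl)amino in place of 6-fluoropyridin-2-yl on a carbonyl carbon. Within the data shown here, one measured step bears on this change, a number 25 percentage points lower from compound 1 to compound 3 (beyond the scatter), which shows that moving from a six-membered carbon-only ring to the 6-fluoropyridin-2-yl group on that carbonyl carbon lowered the number by a modest but real amount. Compound 4 reverses that move, returning to a carbon-only ring, and it also carries a (substituted phenyl)amino group on the same carbonyl carbon as compound 2 does, the compound with the highest number. Among the measured compounds shown here, no measured step matches the new change exactly, so the size of the effect is uncertain.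

Compound 4 is therefore expected to rise by a number 24.5 percentage points higher from compound 3 to compound 4 (beyond the scatter), and its estimated value in this assay is 80%, between 58% and 97%.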

Compound 4, percent growth inhibition at one concentration: 83.8%
Compound 4: the middle estimate sits 3.8 percentage points below what was measured; measured number inside the range.
By their numbers in this assay, from the lowest: compound 3; then compounds 1 and 4 (each within the scatter of the next); then compound 2.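

In this assay, among these compounds, the change to (4-fluorophenyl)amino on the carbonyl carbon gives a number 28.3 percentage points higher from compound 3 to compound 4 (beyond the scatter), so this position responds to more than the one earlier swap of 4-chlorophenyl for 6-fluoropyridin-2-yl. Among the compounds shown here, until now, a (substituted phenyl)amino group on this carbonyl carbon had been seen only with 4-methylpiperazin-1-yl on its ring, and the step to fluoro on that aromatic carbon, a number 11.2 percentage points lower from compound 2 to compound 4 (beyond the scatter), shows that a modest part of the high number depends on that substituent. Set against the 4-chlorophenyl group on the same carbonyl carbon, the (4-fluorophenyl)amino group gives a number 3.3 percentage points higher from compound 1 to compound 4 (within the scatter), so this assay does not tell these two groups apart, even though they attach to the carbonyl carbon differently.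

From the compounds shown here alone, it remains open how a morpholin-4-yl or a dimethylamino group on that aromatic carbon would stand against fluoro and 4-methylpiperazin-1-yl. Nothing given here explains why any of these changes moves the number as it does.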